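The source may report more compounds than this note shows. Statements on the series, on what has been measured and on what is new or still open speak of the compounds shown alone.

Compound 1, `COc1cc(/C=C\c2ccc3ccccc3n2)cc(OC)c1OC`: in a functional assay on A549 cells (Homo sapiens) for cytotoxicity (on this read-out lower numbers stand for stronger inhibition and higher numbers for weaker inhibition), compound 1 gives 316 nM.
Compound 2, `COc1cc(/C=C/c2cnc3ccccc3c2)cc(OC)c1OC`: in this assay compound 2 gives > 3160 nM, which is a limit of the assay and not a number.
Compound 3, `COc1cc(/C=C\c2ccc3cccnc3c2)cc(OC)c1OC`: in this assay compound 3 gives 158 nM.

Among the two compounds that give a number, compound 3 has the lower one, but its gap to compound 1 lies within the usual scatter, so the two cannot be ranked against each other. The third value is only a limit.

Compound 4, `COc1cc(/C=C/c2ccc3cccnc3c2)cc(OC)c1OC`, has not yet been measured. Compared with compound 3, the change is this: the two compounds have the same atoms and bonds and differ only in configuration as drawn: 1 of 1 stereo elements differ; a double bond is drawn Z in compound 3 and E in compound 4. Among the measured compounds shown here, no pair of measured compounds differs in exactly this way, so the size of the step has to be guessed. For the measured compounds named here, the one compound among the three that is drawn E at that double bond, compound 2, sits at the limit, as recorded in the limit of > 3160 nM in this assay, at which 1 of the 3 values shown sits; it also carries its ring attached at a different point, so it is not a clean guide. Still, the step from compound 3 to compound 4 is expected to move toward weaker inhibition, by more than the scatter, as a 19-fold higher number from compound 3 to compound 4 (1.28 log units; beyond the scatter). For compound 4 the estimate is 3000 nM, with a range from 800 nM to 12000 nM, and a fair chance that only a limit is reported.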

Compound 4, half-maximal inhibitory concentration: 1580 nM
Compound 4: middle estimate off by 1.9-fold (0.28 log units), on the high side; the range from low to high includes it.
By their numbers in this assay, from the lowest: compounds 3 and 1 (each within the scatter of the next); then compound 4. At a limit, above all of these: compound 2.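

Changing only the geometry of the double bond, from Z to E, matters in this assay: it gives a 10-fold higher number from compound 3 to compound 4 (1.00 log units; beyond the scatter), a step beyond the usual scatter of repeated measurements. The change in inhibition can be tied to that double bond alone, and not to any added or removed group, because of this: the fact that compounds 3 and 4 differ only in the configuration as drawn. Among the compounds shown here, compound 2, the only earlier compound drawn E, sits at a limit, > 3160 nM, and its ring is attached at a different point, so it could not show the effect of the double bond on its own.

As far as these compounds go, whether the same switch from Z to E would cost as much with the ring attached as in compound 1 remains open, so this step is known for one attachment point only. Also open, from the compounds shown here alone, is how an amine or a hydroxyl group on the core, or an amide in place of the double bond, would affect the inhibition, and whether the gap between the Z and E forms would survive such a change.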